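A few compounds are considered here, and "the series" means these few. Any claim that something is new, unique, unknown or untested is made for them only; others in the source may bear on it.

Compounds 1, 2 and 3 share one core and differ only in the aromatic group on the carbon that carries a double bond to nitrogen. Compound 1 `Nc1nc(N/N=C/c2cccnc2Cl)nc2c1ncn2[C@@H]1O[C@H](CO)[C@@H](O)[C@H]1O` gives 4.6 nM in an assay on CHO-K1 cells for displacement of a labelled ligand from adenosine receptor A1 (Homo sapiens), read by scintillation counting, with a stated time of 60 min; a lower number here means a stronger inhibitor, a higher number a weaker inhibitor. Compound 2 `Nc1nc(N/N=C/c2ccc(Br)cn2)nc2c1ncn2[C@@H]1O[C@H](CO)[C@@H](O)[C@H]1O` gives 4.7 nM in this assay, and compound 3 `Nc1nc(N/N=C/c2ccc[nH]2)nc2c1ncn2[C@@H]1O[C@H](CO)[C@@H](O)[C@H]1O` gives 8 nM in this assay. Compound 3 holds the highest of the three numbers, yet the steps of a 1.7-fold higher number from compound 2 to compound 3 (0.23 log units; within the scatter) and a 1.7-fold higher number from compound 1 to compound 3 (0.24 log units; within the scatter) both lie within the scatter, as does the step of a 1.0-fold higher number from compound 1 to compound 2 (0.01 log units; within the scatter), so the three cannot be ordered. Compound 4 `CCCCc1nc(/C=N/Nc2nc(N)c3ncn([C@@H]4O[C@H](CO)[C@@H](O)[C@H]4O)c3n2)c(Cl)[nH]1` has not yet been measured in this assay. It differs from compound 3 in one place: 2-butyl-5-chloro-1H-imidazol-4-yl in place of 1H-pyrrol-2-yl on a carbon with a double bond to nitrogen. Every measured step exchanged one aromatic group for another on this same carbon, and none moved the number beyond the scatter. For the measured compounds named here, the present exchange brings in a larger group carrying a butyl chain and a chlorine, and no measured step tests a change of that extent, so the uncertainty is wider. Compound 4 is expected to give 10 nM, within a range of 3 nM to 40 nM. This estimate means an expected step of a 1.3-fold higher number from compound 3 to compound 4 (0.10 log units; within the scatter), within the scatter.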

Compound 4, inhibition constant: 12 nM
For compound 4 the middle estimate is 1.2-fold (0.08 log units) below the measured one; the range from low to high includes it.
By their numbers in this assay, from the lowest: compounds 1, 2, 3 and 4 (each within the scatter of the next, the first and the last beyond it).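

Within the scatter, this position accepts a group of 10 heavy atoms in place of one of 5: in this assay, the exchange of 1H-pyrrol-2-yl for 2-butyl-5-chloro-1H-imidazol-4-yl gives a 1.5-fold higher number from compound 3 to compound 4 (0.18 log units; within the scatter). For the compounds shown here, the same group also yields the first steps at this carbon to pass the scatter, though only modestly, with a 2.6-fold higher number from compound 2 to compound 4 (0.41 log units; beyond the scatter) and a 2.6-fold higher number from compound 1 to compound 4 (0.42 log units; beyond the scatter), each starting from a halogen-bearing pyridinyl group. No supporting data bear on what lies behind these steps.

The butyl chain and the chlorine enter together, so the compounds shown do not separate what each contributes. Also open, from the compounds shown here alone, is how the number would respond to a longer chain, or to an amine or a carboxylic acid in place of the butyl chain.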